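Changing the Ring on the Sulfonyl Sulfur

A few compounds are considered here, and "the series" means these few. Any claim that something is new, unique, unknown or untested is made for them only; others in the source may bear on it.

Three compounds share one core and differ only in the ring attached to the sulfonyl sulfur. Compound 1 `CC1CCN(C2CCN(S(=O)(=O)c3cccnc3F)CC2)CC1` carries a 2-fluoropyridin-3-yl group there; in a functional assay on DLD-1 cells (Homo sapiens) for antiproliferative activity, read by CellTiter-Glo, with a stated time of 72 h (a lower number here means a stronger inhibitor, a higher number a weaker inhibitor), compound 1 gives only a limit of > 5000 nM. Compound 2 `CC1CCN(C2CCN(S(=O)(=O)c3nccn3C)CC2)CC1` carries a 1-methyl-1H-imidazol-2-yl group; in this assay compound 2 likewise gives only a limit of > 5000 nM. Compound 3 `CC1CCN(C2CCN(S(=O)(=O)c3cccc(Cl)c3)CC2)CC1` carries a 3-chlorophenyl group; in this assay compound 3 also gives only a limit of > 5000 nM. Because every value sits at the same limit (the limit of > 5000 nM in this assay, at which 3 of the 3 values shown sit), none of the steps can be read: a step that the two limits leave unreadable from compound 1 to compound 2, a step that the two limits leave unreadable from compound 1 to compound 3 and a step that the two limits leave unreadable from compound 2 to compound 3 all remain unreadable in size and direction. Compound 3 therefore stands where the other two stand, at the limit, with no number of its own.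

Compound 4 `CCc1ccc(S(=O)(=O)N2CCC(N3CCC(C)CC3)CC2)cc1` is not yet measured. It differs from compound 3 in one place: 4-ethylphenyl in place of 3-chlorophenyl on a sulfonyl sulfur. For the measured compounds named here, no measured step tells how this ring exchange shifts this assay, since every measured step is unreadable; what the measured compounds show is that three different rings on the sulfonyl sulfur all left the activity at the limit. Compound 4 is expected to stay near that limit as well, an expected step that the limit leaves unreadable from compound 3 to compound 4. The estimate for compound 4 in this assay is 8000 nM, within a range from 3000 nM to 30000 nM.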

Compound 4, half-maximal inhibitory concentration: > 5000 nM
Compound 4: no number, only a limit; the forecaster's own chance of this, stated with the estimate: 80%; the middle value lies beyond the limit too.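

Compound 4 sits at the same limit as compound 1, compound 2 and compound 3, so the steps from those three compounds to compound 4 cannot be read in size or direction in this assay: the limit of > 5000 nM in this assay, at which 4 of the 4 values shown sit. The compounds shown leave open how these four rings on the sulfonyl sulfur rank against one another, and whether any other ring there would give a measurable value.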